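Removing the Acetyl Carbonyl from Compound 1

The compounds below may be only part of what the source reports. "The series", "measured", "known", "first", "only" and "open" are said of these compounds alone.

Compound 1 `CC(=O)N1CCC[C@H]1C(=O)N1CCC(NS(=O)(=O)c2cc(S(=O)(=O)c3ccccc3)ccc2C(F)(F)F)CC1` was tested in an assay on isolated protein for binding affinity to secreted frizzled-related protein 1 (Homo sapiens), read by fluorescence (on this read-out lower numbers stand for stronger inhibition and higher numbers for weaker inhibition), and gives 160 nM. Among the measured compounds shown here, of the two numbers measured so far this is the higher one; its nearest neighbour, compound 2 `CC(C)C(=O)N1CCC[C@H]1C(=O)N1CCC(NS(=O)(=O)c2cc(S(=O)(=O)c3ccccc3)ccc2C(F)(F)F)CC1`, gives 40 nM in this assay. For the measured compounds named here, the one measured step at this position, a 4.0-fold lower number from compound 1 to compound 2 (0.60 log units; beyond the scatter), comes from putting isopropyl in place of methyl on the carbonyl carbon, so the acyl group grew and the number fell.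

Compound 3 `CN1CCC[C@H]1C(=O)N1CCC(NS(=O)(=O)c2cc(S(=O)(=O)c3ccccc3)ccc2C(F)(F)F)CC1` takes the opposite route: methyl in place of acetyl on an amine nitrogen in a ring. The carbonyl and its hydrogen-bond acceptor leave and only a methyl stays on the ring nitrogen. Going by the values given here, no measured step tests the loss of the acyl group, so the single step from compound 1 to compound 2 gives only a weak hint that a smaller group at this place may be less favourable. A modest rise is therefore expected, a 2.5-fold higher number from compound 1 to compound 3 (0.40 log units; beyond the scatter). Compound 3 is estimated at 400 nM, within 100 nM to 1600 nM.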

Compound 3, half-maximal inhibitory concentration: 120 nM
The estimate for compound 3 lay 3.3-fold (0.52 log units) above the measured number, within the range that was stated.
By their numbers in this assay, from the lowest: compound 2; then compounds 3 and 1 (each within the scatter of the next).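

In this assay, putting methyl in place of acetyl on the amine nitrogen in the ring gives a 1.3-fold lower number from compound 1 to compound 3 (0.12 log units; within the scatter), so at this place the acetyl carbonyl can leave without a change that stands out from the scatter. The isopropylcarbonyl group does stand apart, with a 3.0-fold higher number from compound 2 to compound 3 (0.48 log units; beyond the scatter), so among these three groups only that one separates from the others. Nothing measured here explains either step.

As far as these compounds go, what stays open is whether an isopropyl group set directly on that amine nitrogen, with no carbonyl, would match compound 2 or stay level with compound 3. A free amine at this nitrogen, or a longer acyl chain such as butanoyl, would show how far the trend seen with compound 2 extends in either direction.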